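From chloro to hydroxy on a shared core

A few compounds are considered here, and "the series" means these few. Any claim that something is new, unique, unknown or untested is made for them only; others in the source may bear on it.

Two compounds have been measured in a functional assay on NCI-H460 cells (Homo sapiens) for cytotoxicity, read by MTT assay, with a stated time of 48 h; a higher number here means a weaker inhibitor, a lower number a stronger inhibitor:

compound 1 `COc1ccc(/C=C/C(=O)/C=C/c2nc3ccccc3n2C)cc1O`: 6900 nM
compound 2 `COc1ccc(/C=C/C(=O)/C=C/c2nc3cc(Cl)ccc3n2C)cc1O`: 7300 nM

Among the compounds with values here, on these numbers, compound 2 cannot be told apart from compound 1, the only other compound measured. Compound 3 `COc1ccc(/C=C/C(=O)/C=C/c2nc3cc(O)ccc3n2C)cc1O` has not yet been measured. It carries hydroxy in place of chloro on an aromatic carbon. Within the data shown here, one measured step bears on this change, since chloro in place of hydrogen on that same aromatic carbon gives a 1.1-fold higher number from compound 1 to compound 2 (0.02 log units; within the scatter). Among the measured compounds shown here, that single step is thin evidence, as no hydroxy compound has a value yet. On that step, no change beyond the scatter is expected in this assay, in either direction. The expected step is a 1.1-fold lower number from compound 2 to compound 3 (0.05 log units; within the scatter). For compound 3 the estimated value is 6500 nM, with an expected range of 3000 nM to 14000 nM.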

Compound 3, half-maximal inhibitory concentration: 7200 nM
Compound 3: middle estimate off by 1.1-fold (0.04 log units), on the low side, and the stated range covers the measured number.
By their numbers in this assay, from the lowest: compounds 1, 3 and 2 (each within the scatter of the next).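

In this assay, hydroxy in place of chloro gives a 1.0-fold lower number from compound 2 to compound 3 (0.01 log units; within the scatter), and hydroxy in place of hydrogen on the same aromatic carbon gives a 1.0-fold higher number from compound 1 to compound 3 (0.02 log units; within the scatter). Where the earlier pair covered chloro alone, this position has now carried hydrogen, chloro and hydroxy with no step beyond the scatter, even though hydroxy brings a hydrogen-bond donor and a hydrogen-bond acceptor that chloro lacks. No measurement offered here accounts for these numbers staying level. From the compounds shown here alone, it remains open whether an amine, a carboxylic acid or a longer chain on this aromatic carbon would also stay within the scatter. Going by these compounds, it is also open whether a change elsewhere on the shared core, such as replacing the methoxy group, would give a step beyond it.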